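The compounds below may be only part of what the source reports. "The series", "measured", "known", "first", "only" and "open" are said of these compounds alone.

Compound 1 `COc1ncnc2c1c(I)cn2[C@@H]1O[C@H](CO)[C@@H](O)[C@H]1O`: > 20000 nM
Compound 2 `CNc1ncnc2c1c(-c1ccccc1)cn2[C@@H]1O[C@H](CO)[C@@H](O)[C@H]1O`: > 20000 nM
Compound 3 `O=c1[nH]cnc2c1c(-c1cccs1)cn2[C@@H]1O[C@H](CO)[C@@H](O)[C@H]1O`: > 20000 nM

All three measured compounds carry the same sugar-bearing core and were tested in a functional assay on HepG2 cells (Homo sapiens) for antiproliferative activity, read by XTT assay, with a stated time of 72 h; on this read-out higher numbers stand for weaker inhibition and lower numbers for stronger inhibition. Compound 1 reaches only the limit > 20000 nM, not a number. Compound 2 likewise stops at the limit > 20000 nM. Compound 3 also ends at the limit > 20000 nM. Among the compounds with values here, every value shown thus rests at the limit of > 20000 nM in this assay, at which 3 of the 3 values shown sit, so no measured compound shows inhibition that the assay can put a number on, and compound 1 stands exactly where the others do.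

Compound 4 `COc1ncnc2c1c(-c1ccsc1)cn2[C@@H]1O[C@H](CO)[C@@H](O)[C@H]1O` differs from compound 1 by thiophen-3-yl in place of iodo on an aromatic carbon. Within the data shown here, no step between measured compounds is known. Compound 4 is expected to show a step of a number no higher from compound 1 to compound 4 (the limit leaves the size open) that stays within the scatter. Compound 4 is estimated at 20000 nM, with a range from 8000 nM to 60000 nM.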

Compound 4, half-maximal inhibitory concentration: 430 nM
Compound 4: middle estimate off by 47-fold (1.67 log units), on the high side; measured number outside the range, below it.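

Replacing iodo with thiophen-3-yl on this aromatic carbon gives an at least 46-fold lower number from compound 1 to compound 4 (1.66 log units; beyond the scatter) in this assay. The group at this one position can therefore separate a compound with no readable inhibition from one with a measured value. Compound 4 is the only compound shown with a number rather than a limit: the limit of > 20000 nM in this assay, at which 3 of the 4 values shown sit.

As far as these compounds go, it remains open whether thiophen-3-yl is unusual here, or whether a furan ring, an amine or a longer chain at this place would also lower the number. This single step cannot show why the number falls.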